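Adding an Amino Group to a Very Weak Inhibitor

A few compounds are considered here, and "the series" means these few. Any claim that something is new, unique, unknown or untested is made for them only; others in the source may bear on it.

Compound 1 `OCc1ccnc(-c2nn(Cc3ccccc3F)c3ncccc23)n1`: 1300 nM
Compound 2 `Cc1cnc(-c2nn(Cc3ccccc3F)c3ncccc23)nc1N`: 675000 nM

In a functional assay (aorta) with Oryctolagus cuniculus as the target (a lower number here means a stronger inhibitor, a higher number a weaker inhibitor), compound 2 stands highest of the two numbers; compound 1 sits far lower, and the step of a 520-fold higher number from compound 1 to compound 2 (2.72 log units; beyond the scatter) is the only measured one. Compound 3 `NCc1cnc(-c2nn(Cc3ccccc3F)c3ncccc23)nc1N` differs from compound 2 by amino in place of hydrogen on a saturated chain carbon bound to an aromatic carbon. Among the measured compounds shown here, the measured step exchanged one whole group for another and so does not speak directly to this smaller change; no measured step bears on it. With nothing to anchor a direction, only a modest move is expected, a 2.3-fold lower number from compound 2 to compound 3 (0.35 log units; beyond the scatter). Compound 3 is therefore estimated at 300000 nM, with a range from 40000 nM to 1500000 nM.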

Compound 3, half-maximal inhibitory concentration: 1400000 nM
Beside the measured number, compound 3's estimate is 4.7-fold (0.67 log units) below it; the range from low to high includes it.
By their numbers in this assay, from the lowest: compound 1; then compound 2; then compound 3.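

In this assay, turning methyl into aminomethyl gives a 2.1-fold higher number from compound 2 to compound 3 (0.32 log units; beyond the scatter). This modest step shows that adding one amino group on a saturated chain carbon bound to an aromatic carbon weakens inhibition slightly rather than strengthening it, a far smaller change than the earlier exchange of whole groups. Nothing available explains this shift. On these data alone, whether a hydroxyl group, a carboxylic acid or a longer chain at this place would follow the same direction remains open.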